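The source may hold more compounds than are shown below. What is called first, only, known or untested is meant among the compounds shown, and "the series" means these compounds.

Compounds measured in a functional assay on HepG2 cells (Homo sapiens) for antiproliferative activity, read by MTT assay, with a stated time of 24 h; on this read-out lower numbers stand for stronger inhibition and higher numbers for weaker inhibition:
- compound 1 `COc1cc(OC)c(-c2coc3cc(OCc4ccc(F)cc4)ccc3c2=O)cc1OC`, 1000 nM
- compound 2 `COc1cc(OC)c(-c2coc3cc(OCc4ccccc4Br)ccc3c2=O)cc1OC`, 2180 nM

Going by the values given here, compound 1 stands at the lower of the two numbers; its only neighbour is compound 2, reached by a 2.2-fold higher number from compound 1 to compound 2 (0.34 log units; beyond the scatter), a change on the benzyl ring.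

Compound 3 `COc1cc(OC)c(-c2coc3cc(OCc4ccc(C(F)(F)F)cc4)ccc3c2=O)cc1OC` differs from compound 1 by trifluoromethyl in place of fluoro on an aromatic carbon. Among the compounds with values here, the step from compound 1 to compound 2 is the only guide: a benzyl-ring change there gave a modest weakening. For compound 3 a similarly modest shift toward a higher number, or none beyond the scatter, is expected; the estimated step is a 1.4-fold higher number from compound 1 to compound 3 (0.15 log units; within the scatter). Compound 3 is estimated at 1400 nM, range 600 nM to 3500 nM.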

Compound 3, half-maximal inhibitory concentration: 890 nM
For compound 3 the middle estimate is 1.6-fold (0.20 log units) above the measured one; low and high end bracket the measured number.
By their numbers in this assay, from the lowest: compounds 3 and 1 (each within the scatter of the next); then compound 2.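

Replacing 4-fluorobenzyl with 4-(trifluoromethyl)benzyl gives no change that can be told from the scatter in this assay, with a 1.1-fold lower number from compound 1 to compound 3 (0.05 log units; within the scatter), so at this place on the ring the larger trifluoromethyl is tolerated as well as fluoro. Compound 2 now stands apart from both other compounds, with a 2.4-fold lower number from compound 2 to compound 3 (0.39 log units; beyond the scatter). No measurement is available to explain these readings.

Still open, from the compounds shown here alone, is whether the gap of compound 2 follows from bromo itself or from its place on the ring, and how an amine or a carboxylic acid on this ring would read.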